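The compounds below may be only part of what the source reports. "The series", "measured", "known", "first", "only" and "open" are said of these compounds alone.

Compound 1 `COc1ccccc1NC(=O)C1NCCc2ccccc21` and compound 3 `O=C(Nc1ccccc1C(F)(F)F)C1NCCc2ccccc21` are built on the same core, whereas compound 2 `O=C(Nc1ccc(C(F)(F)F)cc1)c1nccc2ccccc12` rests on another; the difference between the two cores is not broken down here. In a functional assay on NUGC-3 cells (Homo sapiens) for inhibition, read by sulforhodamine B assay, with a stated time of 48 h (on this read-out higher numbers stand for weaker inhibition of growth and lower numbers for stronger inhibition of growth), compound 1 reaches only a limit of the assay, > 10000 nM. Compound 3 likewise reaches only a limit, > 10000 nM. Compound 2 too gives only a limit, > 10000 nM. The change from compound 3 to compound 1 is methoxy in place of trifluoromethyl on an aromatic carbon, and it produces a step that the two limits leave unreadable from compound 3 to compound 1; the size cannot be read because of the limit of > 10000 nM in this assay, at which 3 of the 3 values shown sit.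

Compound 4 `COc1ccc(NC(=O)c2nccc3ccccc23)cc1` has not yet been measured. It differs from compound 2 by methoxy in place of trifluoromethyl on an aromatic carbon. Going by the values given here, this is the same kind of change as the one from compound 3 to compound 1, not the same: in compound 1 the methoxy stands ortho to a large group, while in compound 4 it stands para to a large group, and the two pairs sit on different cores.

Since every measured value here is a limit, the step expected from compound 2 to compound 4 in this assay is estimated as a number no higher from compound 2 to compound 4 (the limit leaves the size open), resting only on the fact that compound 2 already gives a limit, > 10000 nM, and that the related change from compound 3 to compound 1 stayed at the limit as well. Compound 4 is therefore expected to give about 10000 nM in this assay, most likely reported again as a limit, with an estimated range from 4000 nM to 30000 nM.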

Compound 4, concentration for 50% growth inhibition: > 10000 nM
Compound 4 was reported as a limit; the forecaster's own chance of this, stated with the estimate: 80%; the middle value sits exactly at the limit.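

No step can be read from compound 2 to compound 4, because neither compound gives a number, only a limit: the limit of > 10000 nM in this assay, at which 4 of the 4 values shown sit.

The compounds shown leave open how methoxy and trifluoromethyl compare in this assay on either core, and whether any of these compounds inhibits growth to a measurable degree there.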